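The source may hold more compounds than are shown below. What is called first, only, known or untested is meant among the compounds shown, and "the series" means these compounds.

Measured in a toxicity assay on HepG2 cells (Homo sapiens) for inhibition, read by CellTiter-Glo, with a stated time of 48 h; a lower number here means a stronger inhibitor, a higher number a weaker inhibitor:
compound 1, `COc1ccc2nc(C)cc(OCC(=O)NCc3cc(C)cc(C)c3)c2c1`, gives > 100000 nM, which is a limit of the assay and not a number.
compound 2, `COc1ccc2nc(C)cc(OCC(=O)Nc3ccccn3)c2c1`, gives > 100000 nM, again a limit.
compound 3, `COc1ccc2nc(C)cc(OCC(=O)Nc3ccncn3)c2c1`, gives > 100000 nM, again a limit.

Compound 3 therefore stands where the other two stand: no number is known for it, only (the limit of > 100000 nM in this assay, at which 3 of the 3 values shown sit). The steps within the measured set give no size: a step that the two limits leave unreadable from compound 1 to compound 2, a step that the two limits leave unreadable from compound 1 to compound 3 and a step that the two limits leave unreadable from compound 2 to compound 3 are each unreadable, both ends sitting at the limit of > 100000 nM in this assay, at which 3 of the 3 values shown sit.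

Compound 4, `COc1ccc2nc(C)cc(OCC(=O)Nc3noc(C)c3C)c2c1`, differs from compound 3 in one place: 4,5-dimethyl-1,2-oxazol-3-yl in place of pyrimidin-4-yl on an amide-type nitrogen. Among the compounds with values here, none of the measured steps bears on this change in a readable way; the three amide-nitrogen substituents tried so far all end at a limit, and the change to the 4,5-dimethyl-1,2-oxazol-3-yl group is of the same kind, a small aromatic ring on the amide-type nitrogen. The expectation for compound 4 in this assay is therefore no step beyond the scatter, a step that the limit leaves unreadable from compound 3 to compound 4, with the result most likely again a limit. Compound 4 is estimated at 200000 nM, within 80000 nM to 600000 nM.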

Compound 4, half-maximal inhibitory concentration: > 100000 nM
Compound 4: a limit, no number (the forecaster's own chance of this, stated with the estimate: 85%); the middle value does not contradict the limit.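

Compound 4 also gives only a limit in this assay, so its steps from compound 1, compound 2 and compound 3 cannot be read: the limit of > 100000 nM in this assay, at which 4 of the 4 values shown sit.

The compounds shown leave open whether any substituent on the amide-type nitrogen gives a number rather than a limit in this assay.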